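Acid series: isopropylcarbamoyl for pyridyl on the aryl arm

This account rests on a few compounds, and the source may have more. Where it says the series, first, only, none or still open, it means among the compounds named here.

Among the compounds with values here, compound 3 `O=C(O)c1ccc2noc(-c3ccc(-c4ccncc4)cc3)c2c1` holds the lowest of the three numbers so far: in an assay for inhibition of inositol hexakisphosphate kinase 2 (Homo sapiens), read by colorimetric assay, coupled enzyme assay and malachite green, with a stated time of 120 min, in the presence of a further agent that is not named here (on this read-out higher numbers stand for weaker inhibition and lower numbers for stronger inhibition), compound 3 gives 150 nM. Compound 1 `COC(=O)/C=C/c1ccc2noc(-c3ccccc3)c2c1` gives 1580 nM in this assay, and compound 2 `CN(C)C(=O)/C=C/c1ccc2noc(-c3ccccc3)c2c1` gives 40300 nM. Within the data shown here, the only measured step between two compounds differing in one place is a 26-fold higher number from compound 1 to compound 2 (1.41 log units; beyond the scatter), and it concerns the carbonyl carbon of the unsaturated side chain, not the aryl arm of the core. Compound 4 `CC(C)NC(=O)c1ccc(-c2onc3ccc(C(=O)O)cc23)cc1` differs from compound 3 by isopropylcarbamoyl in place of pyridin-4-yl on an aromatic carbon. Among the measured compounds shown here, no measured step touches a substituent at that place, so the large step seen on the carbonyl carbon gives no direct guide, and the change itself keeps the carboxylic acid and the shared core of compound 3 intact. A step of modest size in this assay is therefore expected, with the direction uncertain: a 2.0-fold higher number from compound 3 to compound 4 (0.30 log units; within the scatter). Compound 4 is estimated in this assay at 300 nM, within a range of 60 nM to 1500 nM.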

Compound 4, half-maximal inhibitory concentration: 350 nM
Beside the measured number, compound 4's estimate is 1.2-fold (0.07 log units) below it; measured number inside the range.
By their numbers in this assay, from the lowest: compound 3; then compound 4; then compound 1; then compound 2.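

Within the data shown here, compound 4 gives the first measured step at this place, on an aromatic carbon para to a large group: in this assay, a 2.3-fold higher number from compound 3 to compound 4 (0.37 log units; beyond the scatter), which is modest beside the large 26-fold higher number from compound 1 to compound 2 (1.41 log units; beyond the scatter) on the carbonyl carbon. With the carboxylic acid and the shared core held constant, pyridin-4-yl, a six-membered aromatic ring, can give way to isopropylcarbamoyl, which has no ring, and compound 4 still gives 350 nM. No measurement shown offers an explanation for this step.

The pair does not separate the loss of the ring from the arrival of the amide hydrogen, as both change together. Dimethylcarbamoyl and pyridin-3-yl at this place would test each part, and the effect of a longer chain on the amide nitrogen also remains open.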